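A few compounds are considered here, and "the series" means these few. Any claim that something is new, unique, unknown or untested is made for them only; others in the source may bear on it.

In a functional assay on the whole organism (strain Kunming) with Mus musculus as the target, with a stated time of 0.5 h (a higher number here means that more compound is needed for the effect, a lower number that less compound is needed), compound 1 `COc1cc(OC)c(OC)cc1/C=C/COC(=O)/C=C/c1ccc(Br)cc1` gives > 300 mg/kg, which is a limit of the assay and not a number. In this assay compound 2 `COc1ccc(/C=C/C(=O)OC/C=C/c2cc(OC)c(OC)cc2OC)cc1` gives > 300 mg/kg, again only a limit. The record so far is thus (the limit of > 300 mg/kg in this assay, at which 2 of the 2 values shown sit), and compound 2 stands at that limit with no number of its own. Compound 3 `COc1cc(OC)c(OC)cc1/C=C/COC(=O)/C=C/c1ccc(Cl)cc1` keeps the core of compound 2 and changes one group: chloro in place of methoxy on an aromatic carbon, turning 4-methoxyphenyl into 4-chlorophenyl. Going by the values given here, the one measured step bearing on this change is a step that the two limits leave unreadable from compound 1 to compound 2, a swap at the same place, and it offers no size to carry over. Among the compounds with values here, with that step as the only guide, no change beyond the scatter is expected in this assay, in either direction. The estimated step is a step that the limit leaves unreadable from compound 2 to compound 3. Compound 3 is expected at 350 mg/kg, with an estimated range of 200 mg/kg to 700 mg/kg.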

Compound 3, dose for half-maximal effect: > 200 mg/kg
Compound 3 ended at the assay's limit; the forecaster's own chance of this, stated with the estimate: 80%; the middle value is on the limit's open side.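

No step can be read between compound 1, compound 2 and compound 3 in this assay: all three stand at limits of the assay and not at numbers. The compounds shown leave open whether bromo, methoxy or chloro at this place changes the dose needed for half-maximal effect.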